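Notes on the step from compound 3 to compound 4

The compounds below may be only part of what the source reports. "The series", "measured", "known", "first", "only" and "open" are said of these compounds alone.

Measured in a functional assay on KB cells (Homo sapiens); a lower number here means that less compound is needed, a higher number that more compound is needed for the effect:
- compound 1 `Oc1nc(-c2ccccc2F)nc2ccccc12`: 17.5 ug/mL
- compound 2 `Oc1nc(-c2cccc(F)c2)nc2ccccc12`: 8.5 ug/mL
- compound 3 `COc1cc2nc(-c3ccccc3F)nc(O)c2cc1OC`: < 5 ug/mL, a limit

Compound 3 has no exact number in this assay: its < 5 ug/mL is a limit and not a measured value. As far as these compounds go, it is the only such entry (the limit of < 5 ug/mL in this assay, at which 1 of the 3 values shown sits), so its true position remains open.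

Compound 4 `COc1cc2nc(-c3cccc(F)c3)nc(O)c2cc1OC` has the same core as compound 3, with 3-fluorophenyl in place of 2-fluorophenyl on an aromatic carbon, between two ring nitrogen atoms (3-fluorophenyl in place of 2-fluorophenyl on an aromatic carbon).

Going by the values given here, the only other guide is a pair on a different core. Compound 1, with 2-fluorophenyl, gives 17.5 ug/mL. Compound 2, with 3-fluorophenyl, gives 8.5 ug/mL. One pair is thin support, and it cannot be carried over directly to a compound known only by a limit.

No step beyond the usual scatter is therefore expected in this assay, with a slight lean towards a lower number. The expected step is a step that the limit leaves unreadable from compound 3 to compound 4. For compound 4 the estimate is 3.5 ug/mL, with an expected range from 1.2 ug/mL to 9 ug/mL.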

Compound 4, concentration for half-maximal effect: > 20 ug/mL
Compound 4 ended at the assay's limit; the forecaster's own chance of this, stated with the estimate: 50%; middle value at least 5.7-fold (0.75 log units) from the limit.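

In this assay, placing 3-fluorophenyl in place of 2-fluorophenyl on the aromatic carbon between two ring nitrogen atoms gives an at least 4.0-fold higher number from compound 3 to compound 4 (0.60 log units; beyond the scatter), so on the core of compound 3 this position is sensitive to where the fluorine stands on the phenyl ring. The core of compound 1 does not read the same way, since compound 1 gives 17.5 ug/mL and compound 2, with 3-fluorophenyl, gives 8.5 ug/mL, a lower number rather than a higher one; the same change therefore does not carry over between the two cores, although this rests on just these two pairs. Compound 4 gives > 20 ug/mL, and the step can be read only as a minimum because this value is a limit: the limit of > 20 ug/mL in this assay, at which 1 of the 4 values shown sits.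

As far as these compounds go, the true size of the step also stays open because compound 3 is known only by a limit: the limit of < 5 ug/mL in this assay, at which 1 of the 4 values shown sits. Also open is whether the sensitivity extends beyond fluorine, for example to a 4-fluorophenyl, a chlorophenyl or an aminophenyl group at this position on either core.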